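Opening the Five-Membered Ring of Compound 2

The compounds below may be only part of what the source reports. "The series", "measured", "known", "first", "only" and "open" are said of these compounds alone.

Measured in a functional assay on MCF7 cells (Homo sapiens) for antiproliferative activity; on this read-out higher numbers stand for weaker inhibition of growth and lower numbers for stronger inhibition of growth:
- compound 1 `CC/C=C\[C@H](C)[C@H](OC(N)=O)[C@@H](C)[C@H](O)[C@@H](C)C/C(C)=C\[C@H](C)[C@@H](O)[C@@H](C)/C=C\[C@@H](O)C[C@@H]1OC(=O)[C@H](C)C[C@H]1C`: 5.8 nM
- compound 2 `CC/C=C\[C@H](C)[C@H](OC(N)=O)[C@@H](C)[C@H](O)[C@@H](C)C/C(C)=C\[C@H](C)[C@@H](O)[C@@H](C)/C=C\[C@@H](O)C[C@H]1CCC(=O)O1`: 6.4 nM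

Not yet measured: compound 3 `CC/C=C\[C@H](C)[C@H](OC(N)=O)[C@@H](C)[C@H](O)[C@@H](C)C/C(C)=C\[C@H](C)[C@@H](O)[C@@H](C)/C=C\[C@@H](O)C[C@H](O)[C@H](C)C[C@H](C)C(=O)OC`.

In this assay compound 2 gives 6.4 nM, level within the scatter with compound 1 at 5.8 nM. Compound 3 differs from compound 2 by a group of 11 heavy atoms (8 carbon, 3 oxygen; no ring) in place of a group of 6 heavy atoms (4 carbon, 2 oxygen; one five-membered non-aromatic ring with 1 hetero atom), on a saturated chain carbon, two bonds along the chain from a double-bonded chain carbon and an oxygen on a saturated carbon. Among the compounds with values here, the only measured step, a 1.1-fold higher number from compound 1 to compound 2 (0.04 log units; within the scatter), swapped one ring for a smaller ring and stayed within the scatter. Within the data shown here, no measured step removes the ring, so that tolerance is only a weak guide here, and a modest move towards weaker growth inhibition is expected. The estimated change is a 2.8-fold higher number from compound 2 to compound 3 (0.45 log units; beyond the scatter). Compound 3 is expected at 18 nM, with an estimated range of 6 nM to 80 nM.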

Compound 3, concentration for 50% growth inhibition: 1000 nM
Beside the measured number, compound 3's estimate is 56-fold (1.74 log units) below it; measured number above the stated range.
By their numbers in this assay, from the lowest: compounds 1 and 2 (each within the scatter of the next); then compound 3.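

Replacing the ring with the ring-free group of 11 heavy atoms in this assay gives a 160-fold higher number from compound 2 to compound 3 (2.19 log units; beyond the scatter), and the comparison with the larger ring gives a 170-fold higher number from compound 1 to compound 3 (2.24 log units; beyond the scatter). So this position tolerated one ring in place of another, yet growth inhibition weakened sharply once no ring remained. Nothing available here explains this drop.

The compounds shown cannot separate the loss of the ring from the effect of the particular open chain that replaced it. An open chain ending in a carboxylic acid, or one ending in an amine, would be a further test of this position.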